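Bromo substitution on the aryl hydrazone series

The source may report more compounds than this note shows. Statements on the series, on what has been measured and on what is new or still open speak of the compounds shown alone.

Measured in an ADME assay on MT4 cells (Homo sapiens) for cytotoxicity, read by MTT assay, with a stated time of 4 days; on this read-out lower numbers stand for higher toxicity in this test and higher numbers for lower toxicity in this test:
compound 1 `C/C(=N\NC(=O)COc1cccc2ccccc12)c1ccccc1` gives 105 ug/mL
compound 2 `C/C(=N\NC(=O)COc1cccc2ccccc12)c1ccccc1Br` gives 79.8 ug/mL
compound 3 `O=C(COc1cccc2ccccc12)N/N=C/c1ccccc1` gives >= 96.6 ug/mL

The value of compound 3 is a limit of this assay, not a number (the limit of >= 96.6 ug/mL in this assay, at which 1 of the 3 values shown sits). Compound 1 and compound 3 share the naphthyloxyacetyl hydrazide part; the difference between their cores is not broken down here.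

From compound 1 to compound 2 the change is bromo in place of hydrogen on an aromatic carbon, and the step is a 1.3-fold lower number from compound 1 to compound 2 (0.12 log units; within the scatter).

Compound 4 `O=C(COc1cccc2ccccc12)N/N=C/c1cccc(Br)c1` is not yet measured. From compound 3 it differs by bromo in place of hydrogen on an aromatic carbon, the same kind of change as before, though the bromo now sits meta rather than ortho to a large group.

For compound 4 the expected step is an at least 1.0-fold lower number from compound 3 to compound 4 (0.04 log units; that floor lies within the scatter), resting on the step of a 1.3-fold lower number from compound 1 to compound 2 (0.12 log units; within the scatter), which stayed within the scatter. Compound 4 is therefore estimated at 88 ug/mL, with a range from 55 ug/mL to 130 ug/mL.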

Compound 4, half-maximal cytotoxic concentration in the MT4 assay: 87.4 ug/mL
For compound 4 the middle estimate is 1.0-fold (0.00 log units) above the measured one; the measured number falls inside the stated range.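

In the MT4 assay compound 4 gives 87.4 ug/mL, and the bromo change reads an at least 1.1-fold lower number from compound 3 to compound 4 (0.04 log units; that floor lies within the scatter), so the second core gives no sign against the earlier small step, though this does not establish that the step carries over at the same size. The two cores cannot be told apart on this change: the same change on two cores in the MT4 assay, a 1.3-fold lower number (0.12 log units; within the scatter) from compound 1 to compound 2 and an at least 1.1-fold lower number (0.04 log units; that floor lies within the scatter) from compound 3 to compound 4; the limit leaves it open whether they differ Compound 3 has a limit of the assay, not a number, so the true size of the step on this core stays open: the limit of >= 96.6 ug/mL in the MT4 assay, at which 1 of the 4 values shown sits.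

In a physicochemical assay for lipophilicity, measured as octanol-water partition (on this read-out higher numbers stand for higher lipophilicity and lower numbers for lower lipophilicity), compound 3 gives 4.02 and compound 4 gives 4.81. In the physicochemical assay the same change gives a number 0.79 log units higher from compound 3 to compound 4 (beyond the scatter), and one pair cannot show whether this step tracks with the read-out in the MT4 assay. Also open, from the compounds shown here alone, is how an amine or a carboxylic acid in place of the bromo would behave on either core.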